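This account rests on a few compounds, and the source may have more. Where it says the series, first, only, none or still open, it means among the compounds named here.

Working notes on the benzylamide series

Three amides of the shared core have a number in hand: compound 1 `CCCC(N)C(=O)NCc1ccccc1`, compound 2 `C=CCOCC(N)C(=O)NCc1ccccc1` and compound 3 `N[C@@H](C(=O)NCc1ccccc1)C1CCCCC1`. In a functional assay on the whole organism (strain NMRI) with Mus musculus as the target, with a stated time of 30 min (on this read-out lower numbers stand for an effect already at smaller amounts and higher numbers for an effect only at larger amounts of compound), compound 1 gives 120 mg/kg, compound 2 gives 130 mg/kg and compound 3 gives 140 mg/kg. The three numbers lie within the scatter of one another, and compound 2 sits between the other two on this read-out, separated from each by a gap that the scatter covers. Among the compounds with values here, the one step in the set that changes a single place, a 1.1-fold higher number from compound 1 to compound 2 (0.03 log units; within the scatter), puts allyloxy in place of ethyl on the saturated chain carbon and moves nothing beyond the scatter.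

The next compound, compound 4 `C#CCOCC(N)C(=O)NCc1ccccc1`, differs from compound 2 by ethynyl in place of vinyl on a saturated chain carbon bound to an oxygen on a saturated carbon. Within the data shown here, no measured pair carries this exchange of ethynyl for vinyl, so the only guidance is that the same region of the molecule tolerated the step from compound 1 to compound 2 without a shift beyond the scatter. On that basis the step is expected to be no change at the digits printed from compound 2 to compound 4 (within the scatter), with no movement beyond the scatter in either direction. The estimate for compound 4 in this assay is 130 mg/kg, with a range from 80 mg/kg to 220 mg/kg.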

Compound 4, minimum effective dose: 130 mg/kg
Compound 4: middle estimate and measured number agree at the digits printed; low and high end bracket the measured number.
By their numbers in this assay, from the lowest: compounds 1, 2, 4 and 3 (each within the scatter of the next).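

Working notes, continued: in this assay the exchange gives no change at the digits printed from compound 2 to compound 4 (within the scatter) as ethynyl replaces vinyl on a saturated chain carbon bound to an oxygen on a saturated carbon, so at this place a triple bond stands in for a double bond with no shift beyond the scatter. Set against the ethyl of compound 1, propargyloxy gives a 1.1-fold higher number from compound 1 to compound 4 (0.03 log units; within the scatter) and allyloxy gives a 1.1-fold higher number from compound 1 to compound 2 (0.03 log units; within the scatter) in the same assay, so two different unsaturated ethers now show steps from ethyl that both stay within the scatter, with no compound in these steps going against that. No measurement offered here accounts for these numbers or says what, if anything, the two groups have in common beyond their names.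

Every step shown stays within the scatter, so it remains open whether this position can shift the read-out at all. A longer chain, an amine or a carboxylic acid in place of propargyl would test that, and the compounds shown give no indication of what any of these would do to the minimum effective dose.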